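The source may report more compounds than this note shows. Statements on the series, on what has been measured and on what is new or still open speak of the compounds shown alone.

Measured so far in an assay on HEK293 cells for displacement of a labelled ligand from NPC1-like intracellular cholesterol transporter 1 (Homo sapiens); on this read-out lower numbers stand for stronger inhibition and higher numbers for weaker inhibition: compound 1 `CC1(C)CC(OC(=O)CN2CN(c3ccccc3)C3(CCN(C(=O)c4ccc(C(C)(C)C)cc4)CC3)C2=O)CC(C)(C)N1` gives 1300 nM; compound 2 `CC(C)(C)c1ccc(C(=O)N2CCC3(CC2)C(=O)N(CC(=O)N2CCNCC2)CN3c2ccccc2)cc1` gives 22000 nM.

Among the compounds with values here, compound 2 stands at the higher of the two numbers, and the single measured step, a 17-fold higher number from compound 1 to compound 2 (1.23 log units; beyond the scatter), is large. Compound 3 `CC(C)(C)c1ccc(C(=O)N2CCC3(CC2)C(=O)N(CC(=O)N2CCCC(C(N)=O)C2)CN3c2ccccc2)cc1` differs from compound 2 by 3-carbamoylpiperidin-1-yl in place of piperazin-1-yl on a carbonyl carbon. Within the data shown here, no measured step tests the entering group; the one step that touches this carbonyl carbon only shows that exchanges there can move the read-out far. Compound 3 is expected to give 15000 nM (range 5000 nM to 45000 nM), an expected step of a 1.5-fold lower number from compound 2 to compound 3 (0.17 log units; within the scatter) that may stay within the scatter.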

Compound 3, half-maximal inhibitory concentration: 16900 nM
Beside the measured number, compound 3's estimate is 1.1-fold (0.05 log units) below it, within the range that was stated.
By their numbers in this assay, from the lowest: compound 1; then compounds 3 and 2 (each within the scatter of the next).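

In this assay, 3-carbamoylpiperidin-1-yl in place of piperazin-1-yl on this carbonyl carbon gives a 1.3-fold lower number from compound 2 to compound 3 (0.11 log units; within the scatter) and so does not separate the two groups. Within the data shown here, the step of a 13-fold higher number from compound 1 to compound 3 (1.11 log units; beyond the scatter) leaves (2,2,6,6-tetramethylpiperidin-4-yl)oxy as the only one of the three groups with a clearly lower number. No evidence at hand accounts for these steps.

On these data alone, it remains open whether the lower number of compound 1 goes with the linking oxygen or with the tetramethylpiperidine ring; the 2,2,6,6-tetramethylpiperidin-4-ylamino group would separate the two. Also open, as far as these compounds go, is how a carboxylic acid in place of the carbamoyl would read.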